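Hydroxypropyl thioether as the next step from compound 3

The source may report more compounds than this note shows. Statements on the series, on what has been measured and on what is new or still open speak of the compounds shown alone.

Measured so far:
compound 1, `CC(C)c1n[nH]c2c(NCc3ccc(-c4ccccn4)cc3)nc(SCC3CNC(=O)O3)nc12`, 80 nM
compound 2, `CC(C)c1n[nH]c2c(NCc3ccc(-c4ccccn4)cc3)nc(SC(C)C(C)O)nc12`, 190 nM
compound 3, `CC(C)c1n[nH]c2c(NCc3ccc(-c4ccccn4)cc3)nc(SCC(N)CN)nc12`, 480 nM

In a functional assay on HT cells (Homo sapiens) for antiproliferative activity, read by fluorescence, with a stated time of 72 h (a higher number here means a weaker inhibitor of growth, a lower number a stronger inhibitor of growth), compound 3 gives the highest number of the three. Its distance from compound 2 is shown by a 2.5-fold higher number from compound 2 to compound 3 (0.40 log units; beyond the scatter), and its distance from compound 1 by a 6.0-fold higher number from compound 1 to compound 3 (0.78 log units; beyond the scatter), so on these numbers compound 3 is the weakest of the three.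

Compound 4, `CC(C)c1n[nH]c2c(NCc3ccc(-c4ccccn4)cc3)nc(SCCCO)nc12`, differs from compound 3 in one place: 2-hydroxyethyl in place of 1,2-diaminoethyl on a saturated chain carbon bound to a sulfur

The step that bears most on this change is a 2.5-fold higher number from compound 2 to compound 3 (0.40 log units; beyond the scatter), in which a chain carrying a hydroxy group gave way to a chain carrying two amines. Compound 4 returns a hydroxy-bearing chain to the sulfur, so a move back toward the number of compound 2 is expected, and a step of the size of a 2.2-fold lower number from compound 3 to compound 4 (0.34 log units; beyond the scatter) is estimated, toward a lower number. The step from compound 1 to compound 2, a 2.4-fold higher number from compound 1 to compound 2 (0.38 log units; beyond the scatter), shows that chains without a ring can still sit well above compound 1, so a return to that level is not expected. For compound 4 the estimate in this assay is 220 nM, with a range from 100 nM to 500 nM.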

Compound 4, concentration for 50% growth inhibition: 109 nM
Beside the measured number, compound 4's estimate is 2.0-fold (0.30 log units) above it; the range from low to high includes it.
By their numbers in this assay, from the lowest: compounds 1, 4 and 2 (each within the scatter of the next, the first and the last beyond it); then compound 3.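

In this assay, 2-hydroxyethyl in place of 1,2-diaminoethyl on a saturated chain carbon bound to a sulfur gives (a 4.4-fold lower number from compound 3 to compound 4 (0.64 log units; beyond the scatter)), so among these compounds the two amines of compound 3 are not required at this position, and an open chain with a single hydroxy group reaches a level that compound 3 does not. That level cannot be told apart from those of two other compounds: the 3-hydroxypropyl chain of compound 4 matches the 2-hydroxy-1-methylpropyl chain of compound 2 (a 1.7-fold lower number from compound 2 to compound 4 (0.24 log units; within the scatter)), and it also matches the 2-oxo-1,3-oxazolidin-5-yl ring of compound 1 (a 1.4-fold higher number from compound 1 to compound 4 (0.13 log units; within the scatter)), so the ring is not needed to reach this range. Nothing measured here accounts for the gap between the diamine chain and the hydroxy chain.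

The compounds shown leave open whether a chain with a single amine would behave like compound 3 or like compound 4. They also leave open whether the hydroxy group itself matters, which a plain propyl chain, a methyl ether or a carboxylic acid at the end of the chain would help to settle.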